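Amide variation on a shared core: mouse microsomal half-life

This account rests on a few compounds, and the source may have more. Where it says the series, first, only, none or still open, it means among the compounds named here.

Measured compounds:
- compound 1 `CN(C)C(=O)c1ccncc1Nc1cc(-c2ccc3ccn(C)c3c2)c2nccnc2c1` gives 0.35 h in an ADME assay on microsomes from liver (Mus musculus, strain CD-1) for metabolic stability, read by LC-MS, tested at 2 uM; on this read-out higher numbers stand for a longer-lived compound and lower numbers for a shorter-lived compound
- compound 2 `Cn1cc(NC(=O)c2ccncc2Nc2cc(-c3ccc4ccn(C)c4c3)c3nccnc3c2)cn1` gives 0.2 h in this assay
- compound 3 `CC(=O)N1CCCC(NC(=O)c2ccncc2Nc2cc(-c3ccc4ccn(C)c4c3)c3nccnc3c2)C1` gives 0.4 h in this assay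

All three numbers lie within the scatter of one another, so compound 1 is neither distinguished from compound 2 nor from compound 3 on this read-out. The two amide variations that have been measured, a 1.8-fold lower number from compound 1 to compound 2 (0.24 log units; within the scatter) and a 1.1-fold higher number from compound 1 to compound 3 (0.06 log units; within the scatter), and the direct comparison a 2.0-fold higher number from compound 2 to compound 3 (0.30 log units; within the scatter), all stay inside the scatter.

Compound 4 `CN1CCC(N(C)C(=O)c2ccncc2Nc2cc(-c3ccc4ccn(C)c4c3)c3nccnc3c2)C1` differs from compound 1 by 1-methylpyrrolidin-3-yl in place of methyl on an amide-type nitrogen. Both measured steps from compound 1 alter the group on the same carbonyl carbon and neither moves the number beyond the scatter, so the amide substituent appears to have little hold on the read-out in this set of three. The step to compound 4 is therefore expected to be no larger than the scatter, no change at the digits printed from compound 1 to compound 4 (within the scatter). Compound 4 is estimated at 0.35 h, with a range of 0.15 h to 0.8 h.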

Compound 4, half-life: > 1 h
Compound 4: no number, only a limit (the forecaster's own chance of this, stated with the estimate: 5%); at least 2.8-fold (0.45 log units) between middle value and limit.
By their numbers in this assay, from the lowest: compounds 2, 1 and 3 (each within the scatter of the next). At a limit, above all of these: compound 4.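

In this assay compound 4 gives > 1 h, which is a limit and not a number. The group on the amide-type nitrogen can move this read-out after all, which compounds 1, 2 and 3 did not show: 1-methylpyrrolidin-3-yl in place of methyl gives an at least 2.8-fold higher number from compound 1 to compound 4 (0.45 log units; beyond the scatter), and the comparisons with the other two amides give an at least 2.5-fold higher number from compound 3 to compound 4 (0.39 log units; beyond the scatter) and an at least 5.0-fold higher number from compound 2 to compound 4 (0.69 log units; beyond the scatter). These are the first steps in the set beyond the scatter, and their full size stays unread: the limit of > 1 h in this assay, at which 1 of the 4 values shown sits.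

The compounds shown do not separate the ring carbons of the 1-methylpyrrolidin-3-yl group from its ring nitrogen, which a cyclopentyl group at the same place would address. They also leave open whether the methyl kept on the amide-type nitrogen matters, which the matching amide carrying a hydrogen there would test.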